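The compounds below may be only part of what the source reports. "The series", "measured", "known", "first", "only" and "open" are said of these compounds alone.

Working notes on the series.

The series shares one core, and two of its members have been measured in a functional assay (Pituitary gland cell) with Rattus norvegicus as the target; on this read-out lower numbers stand for an effect already at smaller amounts and higher numbers for an effect only at larger amounts of compound. Compound 1, `CC(C)(N)CC(=O)N[C@@H]1CCc2ccccc2N(Cc2ccc(-c3ccccc3-c3nnn(Cc4ccccc4)n3)cc2)C1=O`, gives 1 uM in this assay. Compound 2, `CC(O)Cn1nnc(-c2ccccc2-c2ccc(CN3C(=O)[C@H](NC(=O)CC(C)(C)N)CCc4ccccc43)cc2)n1`, gives 0.05 uM in this assay. For the measured compounds named here, the single measured step, a 20-fold lower number from compound 1 to compound 2 (1.30 log units; beyond the scatter), was large, and compound 2 therefore stands lowest of the two numbers, with compound 1 as its nearest neighbour.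

Compound 3, `COC(=O)c1ccccc1-c1ccc(CN2C(=O)[C@H](NC(=O)CC(C)(C)N)CCc3ccccc32)cc1`, is not yet measured. It differs from compound 2 as follows: methoxycarbonyl in place of 2-(2-hydroxypropyl)-2H-tetrazol-5-yl on an aromatic carbon. Going by the values given here, the one measured step concerns only what is bound to the five-membered aromatic ring with 4 hetero atoms, whereas here that whole ring leaves and a methoxycarbonyl enters; so that step does not bear directly on the change, and no measured pair tells what removal of the ring does. In the absence of such a step the expectation for compound 3 is cautious: a step of a 30-fold higher number from compound 2 to compound 3 (1.48 log units; beyond the scatter) is expected in this assay, towards a higher number, beyond the scatter. Compound 3 is thus estimated at 1.5 uM in this assay, with a range from 0.3 uM to 8 uM.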

Compound 3, concentration for half-maximal effect: 2 uM
Estimate against measurement, compound 3: 1.3-fold (0.12 log units) below; the range from low to high includes it.
By their numbers in this assay, from the lowest: compound 2; then compounds 1 and 3 (each within the scatter of the next).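

In this assay, on this aromatic carbon ortho to a large group, methoxycarbonyl in place of 2-(2-hydroxypropyl)-2H-tetrazol-5-yl gives a 40-fold higher number from compound 2 to compound 3 (1.60 log units; beyond the scatter), so this position responds strongly to this change. Methoxycarbonyl in place of 2-benzyl-2H-tetrazol-5-yl at the same carbon gives a 2.0-fold higher number from compound 1 to compound 3 (0.30 log units; within the scatter), so this second exchange cannot be told apart from no change. Having the five-membered aromatic ring with 4 hetero atoms at this carbon is therefore not enough on its own to give a low number: among these three compounds, only compound 2, with its 2-hydroxypropyl substituent on that ring, stands apart from the other two.

The data at hand offer no measured explanation for either step. The compounds shown leave open how a carboxylic acid at this aromatic carbon would read, and whether a plain propyl chain on the ring, lacking the hydroxyl, would stay close to compound 2 at 0.05 uM or fall with the other two compounds.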